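The source may hold more compounds than are shown below. What is called first, only, known or untested is meant among the compounds shown, and "the series" means these compounds.

Measured so far:
Compound 1, `CCn1c(C(=O)N(CCC#N)CCC#N)ccc1C(CC)(CC)c1ccc(OCCC(O)(CC)CC)c(C)c1`: in an assay on cells for agonist activity at vitamin D3 receptor (Homo sapiens), with a stated time of 96 h (on this read-out lower numbers stand for an effect already at smaller amounts and higher numbers for an effect only at larger amounts of compound), compound 1 reaches only the assay limit of > 10000 nM.
Compound 2, `C#CCCOC(=O)c1ccc(C(CC)(CC)c2ccc(OCCC(O)(CC)CC)c(C)c2)n1CC`: in this assay compound 2 gives 6030 nM.

Compound 2 holds the only number shown in this assay; the other value is a limit. For the measured compounds named here, the single measured step, an at least 1.6-fold lower number from compound 1 to compound 2 (0.21 log units; that floor lies within the scatter), runs from that limit to the number of compound 2, so its true size is open. Compound 3, `CCn1c(C(=O)Nc2cccc(C(F)(F)F)c2)ccc1C(CC)(CC)c1ccc(OCCC(O)(CC)CC)c(C)c1`, differs from compound 2 by (3-(trifluoromethyl)phenyl)amino in place of (but-3-yn-1-yl)oxy on a carbonyl carbon, the new group being (3-(trifluoromethyl)phenyl)amino in place of (but-3-yn-1-yl)oxy on a carbonyl carbon. The measured step bears on this change only loosely, as it also altered the group on the carbonyl carbon, and it lay at the edge of the scatter. No step beyond the scatter is therefore expected in this assay. The estimate for compound 3 is 5000 nM, within 1500 nM to 20000 nM. This amounts to an expected step of a 1.2-fold lower number from compound 2 to compound 3 (0.08 log units; within the scatter).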

Compound 3, half-maximal effective concentration: 5900 nM
For compound 3 the middle estimate is 1.2-fold (0.07 log units) below the measured one; low and high end bracket the measured number.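

In this assay, the carbonyl carbon now has two real numbers to compare, and (3-(trifluoromethyl)phenyl)amino in place of (but-3-yn-1-yl)oxy gives a 1.0-fold lower number from compound 2 to compound 3 (0.01 log units; within the scatter). This place on the shared core therefore took a swap that brings in a six-membered aromatic ring and a hydrogen-bond donor, and removes the triple bond, with no separation between the two values. Compound 1 stands at a limit and not at a number, so an at least 1.6-fold lower number from compound 1 to compound 3 (0.22 log units; that floor lies within the scatter) gives only a floor: the limit of > 10000 nM in this assay, at which 1 of the 3 values shown sits.

What the compounds shown leave open is whether any group on this carbonyl carbon, such as a carboxylic acid, a small amine or a longer chain, would give a number clearly apart from those of compound 2 and compound 3. They also leave open how the read-out responds to changes elsewhere on the shared core.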